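The source may hold more compounds than are shown below. What is called first, only, known or untested is meant among the compounds shown, and "the series" means these compounds.

Measured compounds in a functional assay on A549 cells (Homo sapiens) for antiproliferative activity, read by MTT assay, with a stated time of 48 h; a higher number here means a weaker inhibitor, a lower number a stronger inhibitor:
- compound 1 `CN1CCN(CCCCOc2c(O)cc3oc(-c4ccccc4)cc(=O)c3c2O)CC1` gives > 100000 nM, a limit of the assay rather than a number.
- compound 2 `CCN(CC)CCCCOc1c(OCc2ccccc2)cc2oc(-c3ccccc3)cc(=O)c2c1O` gives 1800 nM.
- compound 3 `O=c1cc(-c2ccccc2)oc2cc(OCc3ccccc3)c(OCCCCN3CCCCC3)c(O)c12` gives 1900 nM.

Compound 1 stands apart from the other two: its result is only a limit, so it is known to be weaker than compound 2 and compound 3, but how much weaker is not known. The unmeasured compound 4 `O=c1cc(-c2ccccc2)oc2cc(O)c(OCCCCN3CCCC3)c(O)c12` differs from compound 1 in one place: pyrrolidin-1-yl in place of 4-methylpiperazin-1-yl on a saturated chain carbon, four bonds along the chain from an oxygen on an aromatic ring.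

Going by the values given here, the only measured step that bears on an amine swap at this position is a 1.1-fold higher number from compound 2 to compound 3 (0.02 log units; within the scatter), and it changes essentially nothing. That step, however, sits on the benzyloxy pair, whereas compound 1 and compound 4 carry a free hydroxyl, and there the swap replaces a different amine. The limit of > 100000 nM in this assay, at which 1 of the 3 values shown sits, gives no number to move from, so the expected step of an at least 1.6-fold lower number from compound 1 to compound 4 (0.22 log units; that floor lies within the scatter) is estimated only loosely, with the chance that compound 4 again returns only a limit. Compound 4 is therefore expected to give about 60000 nM, in the range 8000 nM to 200000 nM.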

Compound 4, half-maximal inhibitory concentration: 51000 nM
Estimate against measurement, compound 4: 1.2-fold (0.07 log units) above; measured number inside the range.
By their numbers in this assay, from the lowest: compounds 2 and 3 (each within the scatter of the next); then compound 4. At a limit, above all of these: compound 1.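

In this assay, pyrrolidin-1-yl in place of 4-methylpiperazin-1-yl on a saturated chain carbon, four bonds along the chain from an oxygen on an aromatic ring, gives an at least 1.9-fold lower number from compound 1 to compound 4 (0.29 log units; that floor lies within the scatter). This is the only amine swap shown on compounds that carry the free hydroxyl, and it turns a result that is only a limit into a measured number, which the swap on the benzyloxy pair could not show. The true size of the step stays unknown, and only its floor can be stated, which lies within the scatter, because compound 1 sits at a limit: the limit of > 100000 nM in this assay, at which 1 of the 4 values shown sits.

Still open, from the compounds shown here alone, is how pyrrolidin-1-yl or 4-methylpiperazin-1-yl would read on the benzyloxy compounds, so the contribution of the amine on that core cannot be set against its contribution on the free-hydroxyl core. Also open, going by these compounds, is whether another amine, such as morpholin-4-yl or dimethylamino, or a longer chain would move the number further on the free-hydroxyl compounds.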